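Working notes: pyridin-3-yl in place of 4-methoxyphenyl

A few compounds are considered here, and "the series" means these few. Any claim that something is new, unique, unknown or untested is made for them only; others in the source may bear on it.

Two compounds of the series have been measured in a functional assay on JAR cells (Homo sapiens) for inhibition, read by MTT assay, with a stated time of 72 h, tested at 10 uM; a higher number here means more inhibition at the concentration tested (going by the name of the read-out), a lower number less inhibition:

compound 1 `CCOC(=O)C1=C(Nc2ccccc2)S/C(=C\c2ccc(OC)cc2)C1=O` gives 32.9%
compound 2 `CCOC(=O)C1=C(Nc2ccc([N+](=O)[O-])cc2)S/C(=C\c2ccc[nH]2)C1=O` gives 54.9%

Compound 1 stands lowest of the two numbers in this assay; its nearest neighbour is compound 2, whose value lies higher by a margin beyond the usual scatter. Within the data shown here, the two compounds differ in more than one place, so no single step between them can be read, and their values show only that the pair sits apart.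

Compound 3 `CCOC(=O)C1=C(Nc2ccccc2)S/C(=C\c2cccnc2)C1=O` is not yet measured. It derives from compound 1 by one change: pyridin-3-yl in place of 4-methoxyphenyl on a double-bonded chain carbon bound to a double-bonded ring carbon. Among the measured compounds shown here, no measured pair isolates this change, so there is no direct basis for the size of the step in this assay. The expectation is a step from compound 1 to compound 3 of a number 2.1 percentage points higher from compound 1 to compound 3 (within the scatter), that is, no movement clearly beyond the scatter in either direction. Compound 3 is therefore estimated at 35%, within a range of 15% to 55%, pending the measurement.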

Compound 3, a percentage reported as inhibition, at one concentration (the size of the read-out at that concentration, not a potency): 32.1%
Estimate against measurement, compound 3: 2.9 percentage points above, within the range that was stated.
By their numbers in this assay, from the lowest: compounds 3 and 1 (each within the scatter of the next); then compound 2.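

In this assay, among these compounds, this is the first step that isolates a single change, and pyridin-3-yl in place of 4-methoxyphenyl on a double-bonded chain carbon bound to a double-bonded ring carbon reads as a number 0.8 percentage points lower from compound 1 to compound 3 (within the scatter). The change replaces a six-membered aromatic ring of carbon only, within a group of 8 heavy atoms, with a six-membered aromatic ring with 1 hetero atom, within a group of 6 heavy atoms, and the counts of hydrogen-bond donors and acceptors stay the same; at this single test concentration, the read-out does not separate the two compounds. No accompanying measurement bears on why the step is this size.

Compound 2 differs from both compound 1 and compound 3 in more than one place, so its steps to them cannot be read, and the contributions of its two differing groups remain unseparated. Going by these compounds, it also remains open whether this position would keep the same read-out with a carboxylic acid, an amine or a longer chain at the same place.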